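Three Limits and a Pyrrole Swap on an Amide

The compounds below may be only part of what the source reports. "The series", "measured", "known", "first", "only" and "open" are said of these compounds alone.

Compound 1 `COc1cc(OC)c2c(=O)cc(C(=O)Nc3ccc(C4CCCCC4)cc3)[nH]c2c1` gives > 43100 nM in a functional assay on HepG2 cells (Homo sapiens) for antiproliferative activity, with a stated time of 72 h; on this read-out lower numbers stand for an effect already at smaller amounts and higher numbers for an effect only at larger amounts of compound; this value is a limit of the assay.
Compound 2 `COc1cc(OC)c2c(=O)cc(C(=O)Nc3ccc(N4CCN(C)CC4)cc3)[nH]c2c1` gives > 19800 nM in this assay; this value is a limit.
Compound 3 `COc1cc(OC)c2c(=O)cc(C(=O)Nc3ccc(Oc4cccnc4)cc3)[nH]c2c1` gives > 32100 nM in this assay; this value is a limit.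

All three measured compounds share a core and differ only in the group on an aromatic carbon of the outer ring. Going by the values given here, compound 3 stands at a limit, and the two other values shown are limits as well, so none of the measured steps can be read: a step that the two limits leave unreadable from compound 1 to compound 2, a step that the two limits leave unreadable from compound 1 to compound 3 and a step that the two limits leave unreadable from compound 2 to compound 3. The change to compound 4 `COc1cc(OC)c2c(=O)cc(C(=O)Nc3ccc(-n4cccc4)cc3)[nH]c2c1` is 1H-pyrrol-1-yl in place of (pyridin-3-yl)oxy on an aromatic carbon. Among the compounds with values here, no measured step bears on it in readable size; the three lines (the limit of > 19800 nM in this assay, at which 1 of the 3 values shown sits), the limit of > 32100 nM in this assay, at which 1 of the 3 values shown sits, and the limit of > 43100 nM in this assay, at which 1 of the 3 values shown sits, show only that every measured group left the compound without a numbered value. The step from compound 3 to compound 4 is therefore expected to be a step that the limit leaves unreadable from compound 3 to compound 4, with no direction readable beyond the scatter. Compound 4 is estimated at 40000 nM, between 10000 nM and 120000 nM, most likely again reported as a limit.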

Compound 4, half-maximal effective concentration: > 77000 nM
Compound 4: a limit, no number; the forecaster's own chance of this, stated with the estimate: 80%; middle value at least 1.9-fold (0.28 log units) away from the limit.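

Compound 4, like compound 1, compound 2 and compound 3, is reported only as a limit of the assay, so no step among these four compounds can be read. The compounds shown leave open how large any effect of changing this group on this assay really is.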